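Swapping chloro for fluoro at the limit of the assay

A few compounds are considered here, and "the series" means these few. Any claim that something is new, unique, unknown or untested is made for them only; others in the source may bear on it.

In a functional assay on HCT-116 cells (Homo sapiens) for cytotoxicity, read by MTT assay, with a stated time of 48 h (a lower number here means a stronger inhibitor, a higher number a weaker inhibitor), compound 1 (`COc1ccc(-c2nc(C(=O)/C=C\Nc3ccc4[nH]ccc4c3)c3ccccn23)cc1`) gives 17400 nM. Compound 2 (`COc1ccc(-c2nc(C(=O)/C=C\Nc3ccc(Cl)cc3)c3ccccn23)cc1`) reads > 30000 nM, which is a limit of this assay and not a number. Compound 3 (`COc1ccc(-c2nc(C(=O)/C=C\Nc3ccc(F)cc3)c3ccccn23)cc1`) differs from compound 2 by fluoro in place of chloro on an aromatic carbon, para to a large group. Among the measured compounds shown here, the only measured step, an at least 1.7-fold higher number from compound 1 to compound 2 (0.23 log units; that floor lies within the scatter), changes the whole group on the amine nitrogen, so it offers only a loose guide. The expected step, an at least 1.0-fold lower number from compound 2 to compound 3 (0.02 log units; that floor lies within the scatter), is estimated to stay within the scatter. For compound 3 the estimate is 28000 nM, with an expected range from 12000 nM to 60000 nM.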

Compound 3, half-maximal inhibitory concentration: > 30000 nM
Compound 3: only a limit was reported; the forecaster's own chance of this, stated with the estimate: 60%; at least 1.0-fold (0.02 log units) between middle value and limit.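

With fluoro in place of chloro, compound 3 stays at a limit of the assay, as compound 2 does, so the step between them cannot be read: the limit of > 30000 nM in this assay, at which 2 of the 3 values shown sit.

In this assay, replacing the 1H-indol-5-yl group on the amine nitrogen with 4-fluorophenyl gives an at least 1.7-fold higher number from compound 1 to compound 3 (0.23 log units; that floor lies within the scatter). Among the three compounds, only compound 1 gives a number rather than a limit, and this now holds for both the 4-chlorophenyl and the 4-fluorophenyl group.

From the compounds shown here alone, it remains open how compound 2 and compound 3 compare beyond the limit. Also open, going by these compounds, is what an amine or a carboxylic acid would give in this same place on the aromatic ring.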